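Swapping the aryl group on the imine of compound 3

The source may report more compounds than this note shows. Statements on the series, on what has been measured and on what is new or still open speak of the compounds shown alone.

Of the compounds shown here, three sharing one core have been measured in an ADME assay on HeLa cells (Homo sapiens) for cytotoxicity, read by MTT assay, with a stated time of 72 h; a lower number here means that less compound is tolerated, a higher number that more compound is tolerated. Compound 1 `Fc1ccc(/C=N/c2sc3c(c2-c2nc4ccccc4s2)CCC3)cc1` gives 372 ug/mL. Compound 2 `Clc1ccccc1/C=N/c1sc2c(c1-c1nc3ccccc3s1)CCC2` gives 138 ug/mL, and compound 3 `Clc1ccc(/C=N/c2sc3c(c2-c2nc4ccccc4s2)CCC3)c(Cl)c1` gives 345 ug/mL. Among the three, compound 3 stands second highest: its number sits within the scatter of compound 1, while compound 2 is clearly lower. For the measured compounds named here, the steps so far all vary the aryl group on the carbon with a double bond to nitrogen: a 2.7-fold lower number from compound 1 to compound 2 (0.43 log units; beyond the scatter), a 1.1-fold lower number from compound 1 to compound 3 (0.03 log units; within the scatter) and a 2.5-fold higher number from compound 2 to compound 3 (0.40 log units; beyond the scatter).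

Compound 4 `Oc1ccccc1/C=N/c1sc2c(c1-c1nc3ccccc3s1)CCC2` is not yet measured. It differs from compound 3 as follows: 2-hydroxyphenyl in place of 2,4-dichlorophenyl on a carbon with a double bond to nitrogen. Going by the values given here, no measured step introduces a hydroxyl at this position, so the expectation rests on the range spanned by the aryl variations already seen, where all three numbers fall within a modest band. Compound 4 is therefore expected to land close to compound 3, with a 1.2-fold lower number from compound 3 to compound 4 (0.09 log units; within the scatter) within or only just beyond the scatter, at an estimated 280 ug/mL (range 120 ug/mL to 500 ug/mL).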

Compound 4, half-maximal cytotoxic concentration: 168 ug/mL
Beside the measured number, compound 4's estimate is 1.7-fold (0.22 log units) above it; low and high end bracket the measured number.
By their numbers in this assay, from the lowest: compounds 2 and 4 (each within the scatter of the next); then compounds 3 and 1 (each within the scatter of the next).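

In this assay, hydroxy in place of chloro on an aromatic carbon gives a 1.2-fold higher number from compound 2 to compound 4 (0.09 log units; within the scatter) and so leaves the two compounds together at the lower level. The other two steps, a 2.1-fold lower number from compound 3 to compound 4 (0.31 log units; beyond the scatter) and a 2.2-fold lower number from compound 1 to compound 4 (0.35 log units; beyond the scatter), show that 2-hydroxyphenyl does not reach the upper level held by 2,4-dichlorophenyl and 4-fluorophenyl, so this position now shows two levels, with the lower one reached by two different groups on the aromatic ring. Nothing at hand explains this split.

The compounds shown leave open whether an amine or a carboxylic acid on this aromatic ring would fall at either level. They also leave open what a saturated chain such as butyl would give on the carbon with a double bond to nitrogen in place of the aromatic ring.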